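The compounds below may be only part of what the source reports. "The series", "measured", "known", "first", "only" and "open" are said of these compounds alone.

Compound 1 `Cn1cnnc1SCC(=O)Nc1ccc(-c2nc(-c3ccccc3)c(-c3ccccc3)n2C)cc1` and compound 2 `Cc1nnc(SCC(=O)Nc2ccc(-c3nc(-c4ccccc4)c(-c4ccccc4)n3C)cc2)s1` share one core and differ only in the heterocycle on the sulfur. In a functional assay on HT-29 cells (Homo sapiens) for cytotoxicity, read by MTT assay, with a stated time of 24 h, tested at 32 ug/mL (on this read-out higher numbers stand for a stronger effect at the one concentration tested and lower numbers for a weaker effect), compound 1 gives 86.1%, and compound 2 gives 87.1%. For the measured compounds named here, the only measured step, a number 1 percentage points higher from compound 1 to compound 2 (within the scatter), shows that swapping one small aromatic heterocycle for another at this sulfur leaves the read-out where it was. Compound 2 stands at the top of the two numbers, but compound 1 sits within the scatter of it, so the two are not distinguished. Compound 3 `Cn1c(-c2ccc(NC(=O)CSC3=NCCS3)cc2)nc(-c2ccccc2)c1-c1ccccc1` differs from compound 2 by a group of 5 heavy atoms (3 carbon, 1 nitrogen, 1 sulfur; one five-membered non-aromatic ring with 2 hetero atoms) in place of a group of 6 heavy atoms (3 carbon, 2 nitrogen, 1 sulfur; one five-membered aromatic ring with 3 hetero atoms), on a sulfur. Going by the values given here, the one measured step bears on this only loosely: there two aromatic rings were exchanged, whereas here the ring that enters is non-aromatic. Among the compounds with values here, with no closer comparison available and the only known step within the scatter, the expected step is none beyond the scatter, a number 3.1 percentage points lower from compound 2 to compound 3 (within the scatter). Compound 3 is estimated in this assay at 84%, between 70% and 95%.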

Compound 3, a percentage reported as activity, at one concentration (the size of the read-out at that concentration, not a potency): 59.4%
Beside the measured number, compound 3's estimate is 24.6 percentage points above it; measured number outside the range, below it.
By their numbers in this assay, from the lowest: compound 3; then compounds 1 and 2 (each within the scatter of the next).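

In this assay, the group on this sulfur does matter: the non-aromatic ring brings a number 27.7 percentage points lower from compound 2 to compound 3 (beyond the scatter) and a number 26.7 percentage points lower from compound 1 to compound 3 (beyond the scatter). The tolerance seen so far therefore covers only the exchange between the two five-membered aromatic rings of compound 1 and compound 2, and it does not extend to the five-membered non-aromatic ring with 2 hetero atoms in compound 3. No measurement at hand accounts for this loss of effect.

From the compounds shown here alone, the entering ring differs from the leaving ones in more than one feature, so it remains open which of them goes with the lower number. Also open, going by these compounds, is whether a six-membered aromatic ring such as pyridin-2-yl, or an open chain such as ethyl, on this sulfur would stay with compound 1 and compound 2 or fall with compound 3.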